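Chloro for bromo on the tribromophenyl sulfonamide

The source may report more compounds than this note shows. Statements on the series, on what has been measured and on what is new or still open speak of the compounds shown alone.

The compounds share one core and differ only in the aryl group on the sulfonamide nitrogen. In an assay on isolated protein for binding affinity to 5-hydroxytryptamine receptor 6 (Homo sapiens) (on this read-out higher numbers stand for weaker inhibition and lower numbers for stronger inhibition), compound 1 `COc1ccc(S(=O)(=O)Nc2cccc(Br)c2)cc1N1CCNCC1` gives 1.26 nM. In this assay compound 2 `COc1ccc(S(=O)(=O)Nc2ccc(C)cc2Br)cc1N1CCNCC1` gives 7.94 nM. In this assay compound 3 `COc1ccc(S(=O)(=O)Nc2cc(Br)cc(Br)c2Br)cc1N1CCNCC1` gives 2.51 nM, the second highest of the three numbers; the step of a 2.0-fold higher number from compound 1 to compound 3 (0.30 log units; within the scatter) stays within the scatter, while the step of a 3.2-fold lower number from compound 2 to compound 3 (0.50 log units; beyond the scatter) lies beyond it.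

Compound 4 `COc1ccc(S(=O)(=O)Nc2cc(Br)cc(Cl)c2Br)cc1N1CCNCC1` is not yet measured. It differs from compound 3 by chloro in place of bromo on an aromatic carbon. Among the measured compounds shown here, no measured step exchanges one halogen for another on the same ring: the steps of a 6.3-fold higher number from compound 1 to compound 2 (0.80 log units; beyond the scatter) and a 3.2-fold lower number from compound 2 to compound 3 (0.50 log units; beyond the scatter) each rebuild the whole substitution pattern of the aryl group, and the step of a 2.0-fold higher number from compound 1 to compound 3 (0.30 log units; within the scatter) adds two bromo groups at once. For the measured compounds named here, the only like-for-like guidance is therefore absent, and the modest size of even the pattern-changing steps suggests a small shift at most. For compound 4 the expectation in this assay is no step beyond the scatter, and the estimate is 3 nM with a range from 1.3 nM to 7 nM. The expected step is a 1.2-fold higher number from compound 3 to compound 4 (0.08 log units; within the scatter).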

Compound 4, inhibition constant: 3.98 nM
Compound 4: the middle estimate sits 1.3-fold (0.12 log units) below what was measured; the range from low to high includes it.
By their numbers in this assay, from the lowest: compounds 1, 3, 4 and 2 (each within the scatter of the next, the first and the last beyond it).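

In this assay, a 1.6-fold higher number from compound 3 to compound 4 (0.20 log units; within the scatter) gives the series its first like-for-like halogen exchange, and chloro in place of bromo at this position, ortho to a bromo group and meta to a bromo group, leaves the number within the scatter. The wider comparisons add a smaller point: a 2.0-fold lower number from compound 2 to compound 4 (0.30 log units; within the scatter) also stays within the scatter, while a 3.2-fold higher number from compound 1 to compound 4 (0.50 log units; beyond the scatter) lies beyond it, whereas a 2.0-fold higher number from compound 1 to compound 3 (0.30 log units; within the scatter) does not, although this separation rests on a single exchange that itself stays within the scatter. No measurement available here bears on why the numbers fall as they do.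

On these data alone, whether the other two bromo groups of the 2,3,5-tribromophenyl group can be exchanged in the same way remains open, as does whether a single exchange on the 3-bromophenyl group of compound 1 would read the same. Groups beyond the halogens at this position, such as methoxy, an amine or a nitrile, have no counterpart among the compounds shown, so how far the position accepts change remains unknown.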